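The source may hold more compounds than are shown below. What is called first, only, known or untested is meant among the compounds shown, and "the series" means these compounds.

Measured so far:
compound 1, `COc1ccc2c(c1)C/C(=C\c1cc(-c3cc(OC)c(OC)c(OC)c3)n[nH]1)C2=O`: 2100 nM
compound 2, `COc1ccc(C(=O)/C=C/c2cc(-c3cc(OC)c(OC)c(OC)c3)n[nH]2)cc1OC`: 510 nM
compound 3, `COc1cc2c(cc1OC)C(=O)/C(=C/c1cc(-c3cc(OC)c(OC)c(OC)c3)n[nH]1)C2`: 2000 nM

In a functional assay on MCF7 cells (Homo sapiens) for inhibition, read by MTT assay, with a stated time of 48 h (a higher number here means a weaker inhibitor, a lower number a stronger inhibitor), compound 1 gives 2100 nM and compound 3 gives 2000 nM. The difference between them is methoxy in place of hydrogen on an aromatic carbon, and that change gave a 1.1-fold lower number from compound 1 to compound 3 (0.02 log units; within the scatter). Compound 2 gives 510 nM in this assay; how its core differs from that of compound 1 is not broken down here. Compound 4, `COc1cc(C(=O)/C=C/c2cc(-c3cc(OC)c(OC)c(OC)c3)n[nH]2)cc(OC)c1OC`, is not yet measured. It differs from compound 2 by methoxy in place of hydrogen on an aromatic carbon. Among the measured compounds shown here, this is the same kind of change as the one from compound 1 to compound 3, though the surroundings differ: there the ring was part of a fused or bridged system of two rings, meta and para to a fused ring, whereas here the ring is not fused and the site is meta to a large group. Because the earlier change gave a 1.1-fold lower number from compound 1 to compound 3 (0.02 log units; within the scatter), a step of a 1.0-fold lower number from compound 2 to compound 4 (0.01 log units; within the scatter) is expected. For compound 4 the estimate in this assay is 500 nM, expected to lie between 200 nM and 1300 nM.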

Compound 4, half-maximal inhibitory concentration: 430 nM
Compound 4: the middle estimate sits 1.2-fold (0.07 log units) above what was measured, within the range that was stated.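

In this assay, methoxy in place of hydrogen on an aromatic carbon gave a 1.2-fold lower number from compound 2 to compound 4 (0.07 log units; within the scatter). Both steps are within the scatter, and they agree with each other: the same change on two cores in this assay, a 1.1-fold lower number (0.02 log units; within the scatter) from compound 1 to compound 3 and a 1.2-fold lower number (0.07 log units; within the scatter) from compound 2 to compound 4, 1.1-fold (0.05 log units) apart, within the scatter of two such steps. On these two cores the change therefore left the number without a readable shift, but two pairs do not show that this would hold on other cores or at other places on the ring.

The compounds shown leave open whether a different group at this site, such as an amine, a carboxylic acid or a longer chain, would move the number beyond the scatter. They also leave open whether removing a methoxy group from the other ring would do so.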